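Exchanging 6-fluoropyridin-3-yl on the shared core

The source may hold more compounds than are shown below. What is called first, only, known or untested is meant among the compounds shown, and "the series" means these compounds.

compound 1 `O=C(Nc1cccc(F)c1)c1cc(=O)[nH]c2cc(-c3ccccc3F)ccc12`: > 20000 nM
compound 2 `O=C(Nc1cccc(F)c1)c1cc(=O)[nH]c2cc(C3=CCOCC3)ccc12`: 10500 nM
compound 3 `O=C(Nc1cccc(F)c1)c1cc(=O)[nH]c2cc(-c3ccc(F)nc3)ccc12`: > 20000 nM

All three compounds were tested in a functional assay on KYSE-70 cells for antiproliferative activity against KYSE-70 cell line (Homo sapiens), read by MTT assay, with a stated time of 72 h; on this read-out lower numbers stand for stronger inhibition and higher numbers for weaker inhibition. Compound 3 gives > 20000 nM, which is a limit of the assay and not a number. Compound 1 gives > 20000 nM, also a limit. Only compound 2 has a numerical value, at 10500 nM.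

Compound 4 `O=C(Nc1cccc(F)c1)c1cc(=O)[nH]c2cc(-c3ccc(F)c(CO)c3)ccc12` has not yet been measured. It differs from compound 3 at one site: 4-fluoro-3-(hydroxymethyl)phenyl in place of 6-fluoropyridin-3-yl on an aromatic carbon. There, 4-fluoro-3-(hydroxymethyl)phenyl stands in place of 6-fluoropyridin-3-yl on an aromatic carbon.

Three measured steps exchange the group at this site. Going by the values given here, the first is a step that the two limits leave unreadable from compound 1 to compound 3. The others are an at least 1.9-fold lower number from compound 1 to compound 2 (0.27 log units; that floor lies within the scatter) and an at least 1.9-fold higher number from compound 2 to compound 3 (0.27 log units; that floor lies within the scatter). None of them therefore shows a size beyond the scatter. Compound 4 keeps a six-membered aromatic ring at the site, as do compound 1 and compound 3, which share (the limit of > 20000 nM in this assay, at which 2 of the 3 values shown sit). Among the compounds with values here, only compound 2, without such a ring, gives a number, so no measured step shows how an aromatic group could improve on the limit. No large gain is expected in this assay, and a second reading at the limit would fit the data. The expected change is an at least 1.3-fold lower number from compound 3 to compound 4 (0.12 log units; that floor lies within the scatter). For compound 4 the estimate is 15000 nM, with an expected range from 5000 nM to 30000 nM.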

Compound 4, half-maximal inhibitory concentration: > 20000 nM
Compound 4 was reported as a limit; the forecaster's own chance of this, stated with the estimate: 45%; middle value at least 1.3-fold (0.12 log units) from the limit.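

In this assay compound 4 gives > 20000 nM, which is a limit of the assay and not a number, so 4-fluoro-3-(hydroxymethyl)phenyl, with its hydrogen-bond donor and larger heavy-atom count, yields no numerical value at this position. The steps to compound 4 from compound 1 and from compound 3 cannot be read, with limits at both ends. The one step that can be read is an at least 1.9-fold higher number from compound 2 to compound 4 (0.27 log units; that floor lies within the scatter), and a third six-membered aromatic ring at this position now joins the others, leaving compound 2, without such a ring, as the only compound here with a numerical value: the limit of > 20000 nM in this assay, at which 3 of the 4 values shown sit.

Going by these compounds, the limits hide how compound 1, compound 3 and compound 4 stand relative to one another, and whether any aromatic group at this position could reach a numerical value remains open. Also open, on these data alone, is whether the reading of compound 2 depends on the ring oxygen of its non-aromatic ring, which a carbon-only cyclohexenyl group would address, and whether an amine or a carboxylic acid on the aromatic ring would change the picture.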